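The compounds below may be only part of what the source reports. "The series", "measured", "known", "first", "only" and "open" are said of these compounds alone.

Measured so far, in a functional assay on Huh-7 cells (Homo sapiens) for antiproliferative activity, read by sulforhodamine B assay, with a stated time of 72 h; a lower number here means a stronger inhibitor, a higher number a weaker inhibitor:
compound 1 `Cc1cccc(COc2ccc(-c3cc(CN4CCN(Cc5ccc(C(F)(F)F)cc5)CC4)no3)cc2)c1` gives 5000 nM
compound 2 `N#Cc1cccc(COc2ccc(-c3cc(CN4CCN(Cc5ccc(C(F)(F)F)cc5)CC4)no3)cc2)c1` gives 100 nM
compound 3 `COc1ccc(COc2ccc(-c3cc(CN4CCN(Cc5ccc(C(F)(F)F)cc5)CC4)no3)cc2)cc1` gives 3200 nM

Compound 3 stands second highest of these three numbers; its nearest neighbour is compound 1, and the gap between them is within the scatter, while a 32-fold higher number from compound 2 to compound 3 (1.51 log units; beyond the scatter) is large. Compound 4 `COc1cc(COc2ccc(-c3cc(CN4CCN(Cc5ccc(C(F)(F)F)cc5)CC4)no3)cc2)cc(OC)c1OC` is not yet measured. The change is 3,4,5-trimethoxyphenyl in place of 4-methoxyphenyl on a saturated chain carbon bound to an oxygen on an aromatic ring. For the measured compounds named here, no measured step adds methoxy groups to this ring, so only an indirect guide exists: a 1.6-fold lower number from compound 1 to compound 3 (0.19 log units; within the scatter) shows that swapping one small ring substituent pattern for another changed little, whereas a 50-fold lower number from compound 1 to compound 2 (1.70 log units; beyond the scatter) shows that a nitrile on that ring moved the number a great deal. With no nitrile introduced here, the expected step is a 1.3-fold lower number from compound 3 to compound 4 (0.11 log units; within the scatter), not beyond the scatter. Compound 4 is therefore estimated at 2500 nM, with a range from 800 nM to 8000 nM.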

Compound 4, half-maximal inhibitory concentration: 500 nM
Estimate against measurement, compound 4: 5.0-fold (0.70 log units) above, outside the stated range (below it).
By their numbers in this assay, from the lowest: compound 2; then compound 4; then compounds 3 and 1 (each within the scatter of the next).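

In this assay the ring on the saturated chain carbon proves sensitive to more than a nitrile, since going from 4-methoxyphenyl to 3,4,5-trimethoxyphenyl gives (a 6.4-fold lower number from compound 3 to compound 4 (0.81 log units; beyond the scatter)). The same group also beats 3-methylphenyl (a 10-fold lower number from compound 1 to compound 4 (1.00 log units; beyond the scatter)), yet 3-cyanophenyl keeps the lowest number (a 5.0-fold higher number from compound 2 to compound 4 (0.70 log units; beyond the scatter)). Nothing available explains why the extra methoxy groups shift the number.

As far as these compounds go, it remains open whether fewer methoxy groups would give the same shift. From the compounds shown here alone, how an amine or a carboxylic acid on this ring would compare also stays unknown.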